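The source may hold more compounds than are shown below. What is called first, only, known or untested is meant among the compounds shown, and "the series" means these compounds.

Compounds measured so far in an ADME assay on MOLT-3 cells (Homo sapiens) for cytotoxicity, with a stated time of 7 days; a lower number here means that less compound is tolerated, a higher number that more compound is tolerated:
- compound 1 `Nc1nc(OCc2ccccc2)c2ncn(/C=C3/CC3(CO)CO)c2n1`: > 20000 nM
- compound 2 `CCCSc1nc(N)nc2c1ncn2/C=C1/CC1(CO)CO`: > 20000 nM
- compound 3 `CCCNc1nc(N)nc2c1ncn2/C=C1/CC1(CO)CO`: "not determined" (no result reported)

In this assay the value for compound 1 is a limit, not a number. For compound 2 the value is likewise a limit. Because of the limit of > 20000 nM in this assay, at which 2 of the 3 values shown sit, the step that the two limits leave unreadable from compound 1 to compound 2 cannot be read in size or direction. Compound 3 has no result in this assay, so there is no number on which it stands; the two other values shown are limits.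

Compound 4 `CCCCOc1nc(N)nc2c1ncn2/C=C1/CC1(CO)CO` is the next compound to be measured. It differs from compound 3 by butoxy in place of propylamino on an aromatic carbon. Among the measured compounds shown here, no measured step bears directly on this change. For the measured compounds named here, the only measured step, from compound 1 to compound 2, is unreadable, and compound 3 itself has no value, so no size or direction of change can be expected from the data beyond the observation that both measured values sit at the limit.

Compound 4 is therefore estimated to tolerate about 20000 nM in this assay, expected to lie between 8000 nM and 60000 nM, most likely again reported only as a limit.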

Compound 4, half-maximal cytotoxic concentration: > 20000 nM
Compound 4: only a limit was reported; the forecaster's own chance of this, stated with the estimate: 80%; the middle value lies on the limit itself.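

In this assay compound 4 gives > 20000 nM, which is a limit and not a number. Its steps from compound 1 and compound 2 cannot be read in size or direction: the limit of > 20000 nM in this assay, at which 3 of the 4 values shown sit.

The compounds shown leave open whether changing the group on the shared core alters tolerance at all, and where compound 3 stands.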